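The source may hold more compounds than are shown below. What is called first, only, known or untested is meant among the compounds shown, and "the series" means these compounds.

Compound 1 `Oc1ccc(/C=C/c2ccccc2O)cc1` and compound 2 `Nc1ccc(/C=C/c2ccccc2O)cc1` share one core; compound 3 `COc1ccc(/C=C/c2cccc(O)c2)cc1` and compound 4 `COc1ccc(/C=C/c2cccc(N)c2)cc1` share another, and the difference between the two cores is not broken down here. In an ADME assay on HEK293 cells (Homo sapiens) for inhibition, read by MTT assay, with a stated time of 2 days (on this read-out lower numbers stand for stronger inhibition and higher numbers for weaker inhibition), compound 1 gives 17.5 ug/mL, compound 2 gives 21.4 ug/mL and compound 3 gives 24 ug/mL.

The change amino in place of hydroxy on an aromatic carbon gave a 1.2-fold higher number from compound 1 to compound 2 (0.09 log units; within the scatter). The change amino in place of hydroxy on an aromatic carbon is the same kind of change, but the group sits para to a group of 9 heavy atoms in the first pair and meta to a large group in the second, so the surroundings differ.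

Because a 1.2-fold higher number from compound 1 to compound 2 (0.09 log units; within the scatter) stayed within the scatter, compound 4 is expected to show a similar small step, a 1.1-fold higher number from compound 3 to compound 4 (0.05 log units; within the scatter), in this assay. The estimated value for compound 4 is 27 ug/mL, with a range from 15 ug/mL to 50 ug/mL.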

Compound 4, half-maximal inhibitory concentration: 11 ug/mL
Compound 4: the middle estimate sits 2.5-fold (0.39 log units) above what was measured; measured number outside the range, below it.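

In this assay, amino in place of hydroxy on an aromatic carbon gave a 2.2-fold lower number from compound 3 to compound 4 (0.34 log units; beyond the scatter), which does not match what the same change did on the core of compound 1. The two cores therefore respond differently to one and the same change: the same change on two cores in this assay, a 1.2-fold higher number (0.09 log units; within the scatter) from compound 1 to compound 2 and a 2.2-fold lower number (0.34 log units; beyond the scatter) from compound 3 to compound 4, 2.7-fold (0.43 log units) apart, beyond the scatter of two such steps. So the step seen on one core could not be carried over to the other here, but two pairs do not show which feature of the cores makes the difference or what the change would do on a further core.

As far as these compounds go, whether another group in that place, such as a fluorine or a carboxylic acid, would follow either step stays open. Also open, from the compounds shown here alone, is which part of the two cores matters.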